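Swapping furan for thiophene on a diterpenoid ester

A few compounds are considered here, and "the series" means these few. Any claim that something is new, unique, unknown or untested is made for them only; others in the source may bear on it.

Measured so far:
compound 1 `C=C1CC[C@@H]2[C@](C)(COC(=O)c3ccco3)[C@H](O)CC[C@@]2(C)[C@@H]1/C=C/C1=CCOC1=O` — 92000 nM
compound 2 `C=C1CC[C@@H]2[C@](C)(COC(=O)c3cccs3)[C@H](O)CC[C@@]2(C)[C@@H]1/C=C/C1=CCOC1=O` — 557000 nM
compound 3 `C=C1CC[C@@H]2[C@](C)(COC(=O)c3ccco3)[C@H](O)CC[C@@]2(C)[C@@H]1C/C=C1\C=COC1=O` — a limit, > 2150000 nM

The three compounds share a core and were tested in an ADME assay on HepG2 2.2.15 cells (Homo sapiens) for cytotoxicity, read by MTT assay; on this read-out lower numbers stand for higher toxicity in this test and higher numbers for lower toxicity in this test. Compound 1 gives 92000 nM. Compound 2 carries thiophen-2-yl in place of furan-2-yl on a carbonyl carbon, and this change made a 6.1-fold higher number from compound 1 to compound 2 (0.78 log units; beyond the scatter). Compound 3 differs from compound 1 in the core, by a group of 8 heavy atoms (6 carbon, 2 oxygen; one five-membered non-aromatic ring with 1 hetero atom) in place of a group of 8 heavy atoms (6 carbon, 2 oxygen; one five-membered non-aromatic ring with 1 hetero atom), on a saturated ring carbon, and this gave an at least 23-fold higher number from compound 1 to compound 3 (1.36 log units; beyond the scatter). For compound 3 only a limit is known, > 2150000 nM, the same limit noted as the limit of > 2150000 nM in this assay, at which 1 of the 3 values shown sits.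

Compound 4 `C=C1CC[C@@H]2[C@](C)(COC(=O)c3cccs3)[C@H](O)CC[C@@]2(C)[C@@H]1C/C=C1\C=COC1=O` has not been measured. Against compound 3 it carries thiophen-2-yl in place of furan-2-yl on a carbonyl carbon, the same change as from compound 1 to compound 2, at the same place. The step is expected to be a step that the limit leaves unreadable from compound 3 to compound 4, resting on the modest rise seen in a 6.1-fold higher number from compound 1 to compound 2 (0.78 log units; beyond the scatter) and on the limit of compound 3 in > 2150000 nM. Compound 4 is thus estimated at 4000000 nM, most likely reported again only as a limit.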

Compound 4, half-maximal cytotoxic concentration: 2470000 nM
For compound 4 the middle estimate is 1.6-fold (0.21 log units) above the measured one, and the stated range covers the measured number.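

On the core of compound 3 the step from furan-2-yl to thiophen-2-yl cannot be read, as compound 3 stands only at a limit: the limit of > 2150000 nM in this assay, at which 1 of the 4 values shown sits. The core change can be read with the thiophen-2-yl ester, where it gives a 4.4-fold higher number from compound 2 to compound 4 (0.65 log units; beyond the scatter) in this assay, and its size depends on which ester is present: the same change on two cores in this assay, an at least 23-fold higher number (1.36 log units; beyond the scatter) from compound 1 to compound 3 and a 4.4-fold higher number (0.65 log units; beyond the scatter) from compound 2 to compound 4, at least 5.2-fold (0.72 log units) apart, beyond the scatter of two such steps. So the rise seen on the first core, a 6.1-fold higher number from compound 1 to compound 2 (0.78 log units; beyond the scatter), is not shown to carry over to the second core, nor shown to fail.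

Within the data shown here, only two ester rings on two cores appear here. As far as these compounds go, how a phenyl ring or a plain alkyl chain on the same carbonyl carbon would behave on either core remains open.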